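A few compounds are considered here, and "the series" means these few. Any claim that something is new, unique, unknown or untested is made for them only; others in the source may bear on it.

Three compounds share one core, an amide bearing a free aromatic amine, joined through a sulfur-containing linker to a nitrogen-bearing group, and they have been tested in a functional assay on A-375 cells (Homo sapiens) for antiproliferative activity, read by CCK-8 assay, with a stated time of 72 h, tested at 8 uM; on this read-out higher numbers stand for a stronger effect at the one concentration tested and lower numbers for a weaker effect. Compound 1, whose structure is `Nc1ccccc1NC(=O)c1ccc(CSC(=S)N2CCN(C(c3ccccc3)c3ccccc3)CC2)cc1`, gives 8.4%. Compound 2, with the structure `CN(C(=S)SCc1ccc(C(=O)Nc2ccccc2N)cc1)c1cccnc1`, gives 87.7%. Compound 3, with the structure `Nc1ccccc1NC(=O)c1ccc(CSC(=S)N2CCN(c3ccc(F)cc3)CC2)cc1`, gives 76.3%. On these three numbers compound 3 stands second highest: compound 2 lies above it by a margin beyond the usual scatter, and compound 1 lies far below it, also beyond the scatter.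

The next compound, compound 4, has the structure `Nc1ccccc1NC(=O)c1ccc(CSC(=S)N2CCN(c3ccccc3F)CC2)cc1`. It is made of the same atoms as compound 3, joined differently, and the difference is 2-fluorophenyl in place of 4-fluorophenyl on an amine nitrogen in a ring. Among the compounds with values here, no pair of measured compounds differs in exactly this way, so no measured step guides the estimate; what is known is that compound 3 already gives a high number in this assay and that large changes of the group on the ring nitrogen, as between compound 1 and compound 3, can move the read-out strongly. Moving a fluorine within the same ring is a smaller change, so a step from compound 3 to compound 4 of a number 11.3 percentage points lower from compound 3 to compound 4 (beyond the scatter) is expected, most likely within the scatter or a modest drop. Compound 4 is therefore estimated at 65%, with a range from 35% to 85%.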

Compound 4, a percentage reported as inhibition, at one concentration (the size of the read-out at that concentration, not a potency): 79.5%
Compound 4: the middle estimate sits 14.5 percentage points below what was measured; measured number inside the range.
By their numbers in this assay, from the lowest: compound 1; then compounds 3, 4 and 2 (each within the scatter of the next, the first and the last beyond it).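

In this assay, putting 2-fluorophenyl in place of 4-fluorophenyl on the amine nitrogen in the ring gives a number 3.2 percentage points higher from compound 3 to compound 4 (within the scatter), so the two read-outs cannot be told apart. Within the data shown here, this is the first measured step at this place on the shared core, and it isolates one small structural difference. The two compounds have the same atoms and only the fluorine sits differently on the phenyl ring; at this one concentration, both of these fluorine placements are compatible with a high read-out. Nothing measured here speaks to the reason for this result.

The compounds shown leave open what the fluorine itself contributes, since a plain phenyl ring on the same nitrogen would be needed to show this, and a chlorine or a methoxy group in the fluorine's place would show whether other groups on this ring give a similar number. this assay reports the size of the effect at a single concentration rather than a potency. Compound 3 and compound 4 could also still differ when compared across a range of concentrations.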